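This account rests on a few compounds, and the source may have more. Where it says the series, first, only, none or still open, it means among the compounds named here.

Compound 1 `COc1cc2c(Oc3ccc(NC(=O)c4nn(-c5ccccc5)c(=O)c5ccccc45)cc3F)ccnc2cc1OCCCN1CCCC1` carries an unsubstituted phenyl on the ring nitrogen of the shared core, and in a functional assay on HT-29 cells (Homo sapiens) for cytotoxicity, read by MTT assay, with a stated time of 72 h (a lower number here means a stronger inhibitor, a higher number a weaker inhibitor), compound 1 gives 980 nM. Compound 2 `COc1cc2c(Oc3ccc(NC(=O)c4nn(-c5ccccc5F)c(=O)c5ccccc45)cc3F)ccnc2cc1OCCCN1CCCC1` adds a fluorine to that phenyl, and compound 2 gives 400 nM. Compound 3 `COc1cc2c(Oc3ccc(NC(=O)c4nn(-c5ccc(Br)cc5)c(=O)c5ccccc45)cc3F)ccnc2cc1OCCCN1CCCC1` instead carries a bromine on the phenyl, and compound 3 gives 670 nM. Among the three numbers compound 2 has the lowest, with the step of a 2.5-fold lower number from compound 1 to compound 2 (0.39 log units; beyond the scatter) lying beyond the scatter, while the gap a 1.7-fold higher number from compound 2 to compound 3 (0.22 log units; within the scatter) stays within it, as does the step of a 1.5-fold lower number from compound 1 to compound 3 (0.17 log units; within the scatter).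

Compound 4 `COc1cc2c(Oc3ccc(NC(=O)c4nn(-c5ccccc5Br)c(=O)c5ccccc45)cc3F)ccnc2cc1OCCCN1CCCC1` is reached from compound 2 by the change (bromo in place of fluoro on an aromatic carbon). Among the measured compounds shown here, the steps that bear on this are the two halogen additions to compound 1, a 2.5-fold lower number from compound 1 to compound 2 (0.39 log units; beyond the scatter) and a 1.5-fold lower number from compound 1 to compound 3 (0.17 log units; within the scatter), both modest, and the comparison of compound 2 with compound 3, which lies within the scatter. On that basis compound 4 is expected to sit close to compound 2, with an estimated step of a 1.3-fold higher number from compound 2 to compound 4 (0.11 log units; within the scatter), not beyond the scatter in either direction. Compound 4 is therefore estimated at 520 nM, within a range from 250 nM to 1100 nM.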

Compound 4, half-maximal inhibitory concentration: 850 nM
Compound 4: middle estimate off by 1.6-fold (0.21 log units), on the low side; the range from low to high includes it.
By their numbers in this assay, from the lowest: compounds 2, 3, 4 and 1 (each within the scatter of the next, the first and the last beyond it).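

In this assay, the halogen on this aromatic carbon, ortho to a large group, makes a difference: going from 2-fluorophenyl to 2-bromophenyl gives a 2.1-fold higher number from compound 2 to compound 4 (0.33 log units; beyond the scatter), a modest step beyond the scatter. The gain seen with fluoro does not carry over to bromo in this place, since adding bromo to the unsubstituted phenyl gives a 1.2-fold lower number from compound 1 to compound 4 (0.06 log units; within the scatter), which is within the scatter. Moving the bromine gives a 1.3-fold higher number from compound 3 to compound 4 (0.10 log units; within the scatter), also within the scatter, so the 2-bromophenyl and 4-bromophenyl groups cannot be told apart here. No measurement shown gives a reason for the difference between fluoro and bromo.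

On these data alone, whether the trend follows the halogen remains open, as chloro in this place would test that. As far as these compounds go, it is also open whether a methoxy or an amine here would behave like fluoro or like bromo.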